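The source may hold more compounds than are shown below. What is called first, only, known or untested is meant among the compounds shown, and "the series" means these compounds.

Going by the values given here, in an ADME assay on L6 cells (Rattus norvegicus) for cytotoxicity, read by resazurin assay, with a stated time of 70 h (on this read-out higher numbers stand for weaker inhibition and lower numbers for stronger inhibition), compound 3 `Cc1c(C(=O)Nc2ccccn2)ccc(F)c1F` gives 308000 nM, the highest of the three numbers so far. Compound 1 `Cc1ccnc(NC(=O)c2ccc(F)c(F)c2C)c1` gives 223000 nM, and compound 2 `Cc1ccccc1C(=O)Nc1cc(-c2ccccc2)ccn1` gives 70000 nM, a clearly lower number than the other two. Compound 4 `Cc1c(F)cccc1C(=O)Nc1ccccn1` differs from compound 3 by hydrogen in place of fluoro on an aromatic carbon. Among the compounds with values here, no measured step covers this exact change. The closest is hydrogen in place of methyl on an aromatic carbon, a 1.4-fold higher number from compound 1 to compound 3 (0.14 log units; within the scatter). On that single precedent, no shift beyond the scatter is expected in this assay. The estimated step is a 1.1-fold lower number from compound 3 to compound 4 (0.06 log units; within the scatter). Compound 4 is expected at 270000 nM, with an estimated range of 130000 nM to 450000 nM.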

Compound 4, half-maximal inhibitory concentration in the L6 assay: 310000 nM
The estimate for compound 4 lay 1.1-fold (0.06 log units) below the measured number; the measured number falls inside the stated range.
By their numbers in the L6 assay, from the lowest: compound 2; then compounds 1, 3 and 4 (each within the scatter of the next).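

In the L6 assay compound 3 gives 308000 nM and compound 4 gives 310000 nM. Going by these compounds alone, in the L6 assay, hydrogen in place of the fluoro group para to a group of 9 heavy atoms gives a 1.0-fold higher number from compound 3 to compound 4 (0.00 log units; within the scatter), the first reading at this position, since the earlier step concerned a methyl group elsewhere. In a physicochemical assay for solubility, read by nephelometry, measured as kinetic solubility, at pH 2, tested at 10 mg/mL (on this read-out lower numbers stand for lower solubility and higher numbers for higher solubility), compound 3 gives 50 ug/mL and compound 4 gives 50 ug/mL. In the physicochemical assay the same change gives no change at the digits printed from compound 3 to compound 4 (within the scatter), so neither read-out separates the two compounds. No supporting data bear on this result. The compounds shown carry only fluoro or hydrogen at this position. As far as these compounds go, what an amine or a carboxylic acid would do there stays open, as does the effect of changing the fluoro group that remains in compound 4.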